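Reshuffling the Acyl Ring of a Diacylhydrazine

The source may hold more compounds than are shown below. What is called first, only, known or untested is meant among the compounds shown, and "the series" means these compounds.

Compound 1 `CC(C)(C)N(NC(=O)c1ccccc1Br)C(=O)c1ccccc1Cl`: 316 nM
Compound 2 `CC(C)(C)N(NC(=O)c1cccc(Cl)c1)C(=O)c1ccccc1Cl`: 155 nM
Compound 3 `CCc1ccc(C(=O)NN(C(=O)c2ccccc2Cl)C(C)(C)C)cc1`: 5.75 nM

In an assay on cells for agonist activity at ecdysone receptor (Bombyx mori), read by a luciferase reporter, with a stated time of 24 h (on this read-out higher numbers stand for an effect only at larger amounts of compound and lower numbers for an effect already at smaller amounts), compound 3 gives the lowest number of the three measured compounds, with compound 2 at a 27-fold lower number from compound 2 to compound 3 (1.43 log units; beyond the scatter) and compound 1 at a 55-fold lower number from compound 1 to compound 3 (1.74 log units; beyond the scatter) away from it. Compound 4 `Cc1ccc(C)c(C(=O)NN(C(=O)c2ccccc2Cl)C(C)(C)C)c1` differs from compound 3 by 2,5-dimethylphenyl in place of 4-ethylphenyl on a carbonyl carbon. Among the measured compounds shown here, no measured step rearranges the same atoms in this way; the two large gains, a 55-fold lower number from compound 1 to compound 3 (1.74 log units; beyond the scatter) and a 27-fold lower number from compound 2 to compound 3 (1.43 log units; beyond the scatter), show only that 4-ethylphenyl clearly outperforms the 2-bromophenyl and 3-chlorophenyl variants in this assay. Since 2,5-dimethylphenyl is neither of these, a moderate loss is expected for compound 4, a 10-fold higher number from compound 3 to compound 4 (1.02 log units; beyond the scatter), with wide uncertainty. Compound 4 is therefore estimated at 60 nM in this assay, between 10 nM and 400 nM.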

Compound 4, half-maximal effective concentration: 1620 nM
Compound 4: middle estimate off by 27-fold (1.43 log units), on the low side; measured number outside the range, above it.
By their numbers in this assay, from the lowest: compound 3; then compound 2; then compound 1; then compound 4.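

In this assay, rearranging the same atoms on this carbonyl carbon from 4-ethylphenyl to 2,5-dimethylphenyl gives a 280-fold higher number from compound 3 to compound 4 (2.45 log units; beyond the scatter), the largest step in the series, so the arrangement alone matters greatly here, with every count unchanged. The 2-bromophenyl and 3-chlorophenyl variants also keep lower numbers than the new group, with a 10-fold higher number from compound 2 to compound 4 (1.02 log units; beyond the scatter) and a 5.1-fold higher number from compound 1 to compound 4 (0.71 log units; beyond the scatter). Nothing given here explains this loss.

The compounds shown leave open whether 4-methylphenyl or 4-propylphenyl would keep a number as low as that of compound 3 5.75 nM. They also leave open which methyl group of 2,5-dimethylphenyl accounts for the loss.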